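Removing a Methoxy Group: Expected Change in Stomach Dose

The source may report more compounds than this note shows. Statements on the series, on what has been measured and on what is new or still open speak of the compounds shown alone.

Compound 1 `CC/N=C(\S)CCn1nc(-c2ccccc2)ccc1=O`: 100 mg/kg
Compound 2 `N=C(S)CCCCCn1nc(-c2ccccc2)ccc1=O`: 23.3 mg/kg
Compound 3 `COc1ccc(-c2ccc(=O)n(CCC(=N)S)n2)cc1`: > 100 mg/kg

In a functional assay on the whole organism (stomach) with Rattus norvegicus as the target (on this read-out higher numbers stand for an effect only at larger amounts of compound and lower numbers for an effect already at smaller amounts), compound 1 gives 100 mg/kg. In this assay compound 2 gives 23.3 mg/kg. Compound 3 reaches only a limit of the assay, > 100 mg/kg, so no number is known for it. Compound 3 thus stands at the limit of > 100 mg/kg in this assay, at which 1 of the 3 values shown sits, the boundary of what this assay reports, and not at a measured point. Going by the values given here, the only step among the measured compounds concerns the chain: a 4.3-fold lower number from compound 1 to compound 2 (0.63 log units; beyond the scatter).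

Compound 4 `N=C(S)CCn1nc(-c2ccccc2)ccc1=O` differs from compound 3 in one place: hydrogen in place of methoxy on an aromatic carbon. Among the compounds with values here, no measured step touches the aromatic ring; the chain step between compound 1 and compound 2 gives neither direction nor size for this change. What remains is that compound 1 and compound 2, which carry the same core without the methoxy group, both return numbers rather than limits. Compound 4 is therefore expected to give a number in this assay, estimated at 60 mg/kg, with a range from 20 mg/kg to 150 mg/kg. The expected step of an at least 1.6-fold lower number from compound 3 to compound 4 (0.22 log units; that floor lies within the scatter) is an estimate from a limit and carries wide uncertainty.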

Compound 4, dose for half-maximal effect: 87.3 mg/kg
Beside the measured number, compound 4's estimate is 1.5-fold (0.16 log units) below it; the measured number falls inside the stated range.
By their numbers in this assay, from the lowest: compound 2; then compounds 4 and 1 (each within the scatter of the next).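

With compound 4, the ring without the methoxy group now has a number beside this short chain, but compound 3 is only a limit in this assay: the limit of > 100 mg/kg in this assay, at which 1 of the 4 values shown sits.

The comparison therefore gives only a floor, an at least 1.1-fold lower number from compound 3 to compound 4 (0.05 log units; that floor lies within the scatter), and it does not show whether swapping methoxy for hydrogen on this aromatic carbon changes the dose at all. The chain comparisons are clearer: one gives a 3.7-fold higher number from compound 2 to compound 4 (0.57 log units; beyond the scatter), and the other gives a 1.1-fold lower number from compound 1 to compound 4 (0.06 log units; within the scatter), so among these three only the long chain group of compound 2 stands apart.

Going by these compounds, how much the methoxy group itself matters stays open, as does the effect of another group at the same ring position, such as chlorine or hydroxyl. On these data alone, it is also open whether a still longer chain, or an amine at the chain end, would lower the number further.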